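The source may hold more compounds than are shown below. What is called first, only, known or untested is meant among the compounds shown, and "the series" means these compounds.

In a functional assay on HCT-15 cells (Homo sapiens) for inhibition (on this read-out lower numbers stand for stronger inhibition and higher numbers for weaker inhibition), compound 1 (`Oc1ccccc1-c1cc(-c2cccc(F)c2)cc(-c2ccccc2O)n1`) sits at a limit, > 50000 nM. Compound 2 (`Oc1cccc(-c2cc(-c3cccc(F)c3)cc(-c3ccccc3O)n2)c1`) also sits at a limit, > 50000 nM. Within the data shown here, the one measured step, a step that the two limits leave unreadable from compound 1 to compound 2, therefore gives no size to carry forward, and the only evidence is the limit of > 50000 nM in this assay, at which 2 of the 2 values shown sit. Compound 3 (`Oc1cccc(-c2cc(-c3cccc(C(F)(F)F)c3)cc(-c3ccccc3O)n2)c1`) has trifluoromethyl in place of fluoro on an aromatic carbon. With no readable step behind it, only a small shift towards stronger inhibition in this assay is expected, and another limit is quite possible. The expected step is an at least 1.2-fold lower number from compound 2 to compound 3 (0.09 log units; that floor lies within the scatter). Compound 3 is estimated at 40000 nM, within an expected range of 12000 nM to 80000 nM.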

Compound 3, half-maximal inhibitory concentration: 6460 nM
Beside the measured number, compound 3's estimate is 6.2-fold (0.79 log units) above it; the measured number lies below the stated range.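

In this assay, among these compounds, the change from 3-fluorophenyl to 3-(trifluoromethyl)phenyl gives an at least 7.7-fold lower number from compound 2 to compound 3 (0.88 log units; beyond the scatter) and so shows that this position can move the read-out, which the earlier compounds did not. Compound 2 with > 50000 nM is a limit, so the step has a floor but no exact size. Compound 3 is the only compound shown with a number rather than a limit: the limit of > 50000 nM in this assay, at which 2 of the 3 values shown sit.

As far as these compounds go, the step from compound 1 to compound 2 cannot be read, so it remains open whether trifluoromethyl would act alike with the 2-hydroxyphenyl arrangement of compound 1. Also open, from the compounds shown here alone, is how a nitrile, a methoxy group or an amine would read at this position.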